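The source may report more compounds than this note shows. Statements on the series, on what has been measured and on what is new or still open speak of the compounds shown alone.

Measured so far:
compound 1, `CC(C)CCc1sc(NC(=O)c2cc(NC(=O)c3cc(NC(=N)c4cnc5ccccc5c4)cn3C)cn2C)nc1C(=O)NCCCN(C)C`: 1.2 ug/mL
compound 2, `CC(C)CCc1sc(NC(=O)c2cc(NC(=O)c3cc(NC(=N)c4ccccc4)cn3C)cn2C)nc1C(=O)NCCCN(C)C`: > 32 ug/mL

Compound 2 is the more tolerated of the two compounds measured in an ADME assay on HEK293 cells (Homo sapiens) for cytotoxicity, read by fluorescence and resazurin assay, with a stated time of 20 h; a lower number here means that less compound is tolerated, a higher number that more compound is tolerated. For compound 2 the value > 32 ug/mL is a limit of the assay rather than a number (the limit of > 32 ug/mL in this assay, at which 1 of the 2 values shown sits). Compound 1, the other measured compound, gives 1.2 ug/mL in this assay. Compound 3, `CC(C)CCc1sc(NC(=O)c2cc(NC(=O)c3cc(NC(=N)c4cccc(Cl)c4)cn3C)cn2C)nc1C(=O)NCCCN(C)C`, differs from compound 2 by chloro in place of hydrogen on an aromatic carbon. Going by the values given here, the single measured step on this part of the molecule is an at least 26-fold higher number from compound 1 to compound 2 (1.42 log units; beyond the scatter), where the quinolin-3-yl is exchanged for a plain phenyl, and it is large. The change from compound 2 to compound 3 is narrower in scope, entering one chlorine on the phenyl rather than exchanging the whole ring, so a step of smaller size than that one is expected, if any. Since compound 2 sits at the limit, even a moderate drop would bring compound 3 into measurable numbers. Compound 3 is expected at 20 ug/mL, with a range from 6 ug/mL to 40 ug/mL. The expected step is an at least 1.6-fold lower number from compound 2 to compound 3 (0.20 log units; that floor lies within the scatter).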

Compound 3, half-maximal cytotoxic concentration: 9.2 ug/mL
For compound 3 the middle estimate is 2.2-fold (0.34 log units) above the measured one; measured number inside the range.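

In this assay the phenyl ring proves sensitive to a single added atom: chloro on an aromatic carbon, meta to a large group, gives an at least 3.4-fold lower number from compound 2 to compound 3 (0.54 log units; beyond the scatter), so this place on the ring is not indifferent to substitution. The substituted ring still keeps part of the gain seen on leaving quinolin-3-yl, with a 7.7-fold higher number from compound 1 to compound 3 (0.88 log units; beyond the scatter), so tolerance in this series does not depend on the phenyl ring being left bare. Compound 2 carries a limit and not a number, so the chloro step has only a lower bound and its full size stays unknown: the limit of > 32 ug/mL in this assay, at which 1 of the 3 values shown sits.

The compounds shown leave open whether the drop belongs to chlorine itself or to any group at this place, which a fluoro, a methyl or a methoxy group on the same carbon would help to separate. Also open, as far as these compounds go, is whether chloro on another carbon of the same ring gives a similar number, and whether an amine or a carboxylic acid there would move the number the other way.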